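Fluoro on the phenyl ring of compound 2

The source may report more compounds than this note shows. Statements on the series, on what has been measured and on what is new or still open speak of the compounds shown alone.

Measured so far:
- compound 1 `N#Cc1ccc(NC(=S)Nc2cccc(C(F)(F)F)c2)cc1`: 10000 nM
- compound 2 `FC(F)(F)c1cccc(NC(=S)Nc2ccccc2)c1`: 39000 nM
- compound 3 `CCOC(=O)c1ccc(NC(=S)Nc2cccc(C(F)(F)F)c2)cc1`: 71000 nM

In an ADME assay on Vero 76 cells (Chlorocebus sabaeus) for cytotoxicity, read by crystal violet staining, with a stated time of 96 h (a higher number here means that more compound is tolerated, a lower number that less compound is tolerated), compound 2 sits with compound 3 and clear of compound 1, the lowest of the three numbers. Compound 4 `Fc1cccc(NC(=S)Nc2cccc(C(F)(F)F)c2)c1` has fluoro in place of hydrogen on an aromatic carbon of compound 2: fluoro in place of hydrogen on an aromatic carbon. For the measured compounds named here, no measured step involves fluoro. The closest evidence is ethoxycarbonyl on compound 3 (a 1.8-fold higher number from compound 2 to compound 3 (0.26 log units; within the scatter)) and, read in reverse, cyano on compound 1 (a 3.9-fold higher number from compound 1 to compound 2 (0.59 log units; beyond the scatter)). These differ in direction, so only a small step is expected, slightly downward and probably inside the scatter. The expected change is a 1.3-fold lower number from compound 2 to compound 4 (0.11 log units; within the scatter). Compound 4 is estimated at 30000 nM, with a range of 11000 nM to 75000 nM.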

Compound 4, half-maximal cytotoxic concentration: 20000 nM
The estimate for compound 4 lay 1.5-fold (0.18 log units) above the measured number; low and high end bracket the measured number.
By their numbers in this assay, from the lowest: compounds 1, 4, 2 and 3 (each within the scatter of the next, the first and the last beyond it).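

In this assay, for the compounds shown here, the change from phenyl to 3-fluorophenyl gives a 2.0-fold lower number from compound 2 to compound 4 (0.29 log units; within the scatter), the only step here with a group meta to a large group on this ring. At this place, a single fluoro therefore leaves compound 4 within the scatter of compound 2, so tolerance is not separated from that of the unsubstituted ring. Nothing measured here bears on the reason for the size of this step.

On these data alone, whether a larger halogen such as chloro, or an amine or a methoxy group, would also stay within the scatter of compound 2 at this place remains open. So does whether fluoro elsewhere on this ring would give a similar number.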